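The compounds below may be only part of what the source reports. "The series", "measured", "known", "first", "only" and "open" are said of these compounds alone.

Compound 1 `CCN(C)C(=O)c1cnc(Oc2cc(C(=O)Nc3cnc(C)cn3)cc3oc(C)cc23)cn1`: < 8 mL/min/kg
Compound 2 `Cc1ccc(NC(=O)c2cc(Oc3cnc(C(=O)N(C)C)cn3)c3cc(C)oc3c2)nc1`: < 10.6 mL/min/kg

Both compounds were tested in an ADME assay (liver) for metabolic stability, with Liver microsome (Homo sapiens) as the target, using microsomes; on this read-out higher numbers stand for fast clearance and lower numbers for slow clearance. Compound 2 stands at < 10.6 mL/min/kg, which is a limit of the assay and not a number. Compound 1 also gives only a limit, < 8 mL/min/kg. Going by the values given here, no measured step connects the two compounds, so neither result gives the size of a structural effect.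

Compound 3 `Cc1cc2c(Oc3cnc(C(=O)N(C)C)cn3)cc(C(=O)Nc3cnc(C(F)(F)F)cn3)cc2o1` has yet to be measured. It carries 5-(trifluoromethyl)pyrazin-2-yl in place of 5-methylpyridin-2-yl on an amide-type nitrogen.

With compound 2 at the limit of < 10.6 mL/min/kg, the expectation can rest only on that limit and the similar result for compound 1. The expected step is a step that the limit leaves unreadable from compound 2 to compound 3, with no change beyond the scatter anticipated in either direction. In this assay, the expected value for compound 3 is 9 mL/min/kg, within an estimated range of 5 mL/min/kg to 18 mL/min/kg.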

Compound 3, clearance: 16.1 mL/min/kg
For compound 3 the middle estimate is 1.8-fold (0.25 log units) below the measured one, and the stated range covers the measured number.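

In this assay, compound 3 alone among the compounds shown gives a number and not a limit, which gives this position its first countable read-out. Placing 5-(trifluoromethyl)pyrazin-2-yl in place of 5-methylpyridin-2-yl on the amide-type nitrogen gives an at least 1.5-fold higher number from compound 2 to compound 3 (0.18 log units; that floor lies within the scatter). This is only a floor, so the true step may be larger, and whether it goes beyond the scatter cannot be read because compound 2 gives only a limit of the assay: the limit of < 10.6 mL/min/kg in this assay, at which 1 of the 3 values shown sits.

The change swaps the ring and its substituent together, so the compounds shown do not tell how much of the step belongs to the added ring nitrogen and how much to the trifluoromethyl group. A 5-(trifluoromethyl)pyridin-2-yl group on the same nitrogen would separate the two.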